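A few compounds are considered here, and "the series" means these few. Any claim that something is new, unique, unknown or untested is made for them only; others in the source may bear on it.

Compound 1 `N#CC1CN1C(=O)Nc1ccc(F)cc1` gives the lowest number of the three measured compounds in a functional assay on A-375 cells (Homo sapiens) for inhibition (a lower number here means a stronger inhibitor, a higher number a weaker inhibitor), with 3400 nM. Compound 3 `N#CC1CN1C(=O)NC1CCCCC1` stands nearest in this assay at 35000 nM, a gap beyond the scatter, and compound 2 `CC(C)(C)NC(=O)N1CC1C#N` stands furthest at 418000 nM. Compound 4 `N#CC1CN1C(=O)Nc1ccc(S(N)(=O)=O)cc1` has not yet been measured in this assay. Compared with compound 1, compound 4 carries sulfamoyl in place of fluoro on an aromatic carbon, that is, sulfamoyl in place of fluoro on an aromatic carbon. For the measured compounds named here, no measured pair differs only at this position, so the size of this step is not fixed by the measured compounds. Compound 4 is expected to show a step of a 1.8-fold higher number from compound 1 to compound 4 (0.25 log units; within the scatter) in this assay, of modest size toward a weaker inhibitor. For compound 4 the estimate is 6000 nM, with a range from 1200 nM to 30000 nM.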

Compound 4, half-maximal inhibitory concentration: 188000 nM
Estimate against measurement, compound 4: 31-fold (1.50 log units) below, and the stated range ends below it.
By their numbers in this assay, from the lowest: compound 1; then compound 3; then compound 4; then compound 2.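

On the aromatic carbon para to a group of 8 heavy atoms, sulfamoyl in place of fluoro gives a 55-fold higher number from compound 1 to compound 4 (1.74 log units; beyond the scatter) in this assay and so a much weaker inhibitor. This single change shows that the substituent at this position can largely set the reading, and that this position does not accept every group equally. No measurement available here bears on the reason for this step. On these data alone, whether a methyl group, an amine or a carboxylic acid at this carbon would stay close to compound 1 or fall toward compound 4 remains open.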